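The source may report more compounds than this note shows. Statements on the series, on what has been measured and on what is new or still open speak of the compounds shown alone.

Working notes on the series. Compound 1 `Nc1scc(CN2CCN(c3ccccc3C(F)(F)F)CC2)c1C(=O)c1ccc(Cl)cc1` and compound 2 `Nc1scc(CN2CCN(c3cccc(F)c3F)CC2)c1C(=O)c1ccc(Cl)cc1` share a core and differ only in the aryl group on an amine nitrogen in a ring. Going by the values given here, in a functional assay on CHO cells with adenosine receptor A1 (Homo sapiens) as the target, read by cAMP accumulation and immunoassay, with a stated time of 6 min, tested at 1 uM (on this read-out higher numbers stand for a weaker effect at the one concentration tested and lower numbers for a stronger effect), compound 1 gives -39%, and compound 2 gives -66%, so compound 2 stands lowest of the two numbers, with compound 1 as its only neighbour. Among the compounds with values here, the one measured step, a number 27 percentage points lower from compound 1 to compound 2 (beyond the scatter), shows that swapping one aryl group for another on this nitrogen can move the read-out by a modest amount.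

Compound 3 `Nc1scc(CN2CCN(c3ccccc3Cl)CC2)c1C(=O)c1ccc(Cl)cc1` follows the same line: 2-chlorophenyl in place of 2,3-difluorophenyl on an amine nitrogen in a ring. Within the data shown here, no measured pair carries this exact change, so only the size of the step from compound 1 to compound 2 offers a scale, and a step of comparable size in this assay, in either direction, is plausible; an estimated shift of a number 16 percentage points higher from compound 2 to compound 3 (beyond the scatter) back toward compound 1 is taken as the working guess. Compound 3 is therefore expected to give -50%, within a range from -78% to -22%.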

Compound 3, a percentage reported as activity, at one concentration (the size of the read-out at that concentration, not a potency): -5.2%
Estimate against measurement, compound 3: 44.8 percentage points below; the measured number lies above the stated range.
By their numbers in this assay, from the lowest: compound 2; then compound 1; then compound 3.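

In this assay, the aryl group on an amine nitrogen in a ring proves far more sensitive than the first pair indicated, with a number 60.8 percentage points higher from compound 2 to compound 3 (beyond the scatter) as a large step. The change to chloro in place of trifluoromethyl on an aromatic carbon gives a number 33.8 percentage points higher from compound 1 to compound 3 (beyond the scatter) and is also large, so exchanging that single group on the aryl ring, with the rest of the structure unchanged, is enough to shift the read-out substantially. Nothing at hand accounts for the size of either step.

On these data alone, whether bromo, methyl or methoxy in place of chloro on the aromatic carbon would stay close to compound 3 remains open, as does the result with unsubstituted phenyl. With one concentration per compound, the order of these three says nothing about their potency.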